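The source may report more compounds than this note shows. Statements on the series, on what has been measured and on what is new or still open speak of the compounds shown alone.

The measured compounds:
compound 1 `CC(C)OC(=O)N1CCC(Oc2ncnc3c2CCN3c2ccc(C#N)cc2F)CC1` 63.1 nM
compound 2 `CC(C)OC(=O)N1CCC(Oc2ncnc3c2CCN3c2ccc(-c3nccs3)cc2F)CC1` 79.4 nM

Among the measured compounds shown here, in a functional assay on CHO-K1 cells for agonist activity at Glucose-dependent insulinotropic receptor (Homo sapiens), read by a luciferase reporter, with a stated time of 5 h (on this read-out lower numbers stand for an effect already at smaller amounts and higher numbers for an effect only at larger amounts of compound), compound 1 gives 63.1 nM, the lowest of the two numbers; the only neighbour is a 1.3-fold higher number from compound 1 to compound 2 (0.10 log units; within the scatter). Compound 3 `CC(C)OC(=O)N1CCC(Oc2ncnc3c2CCN3c2ccc(C#N)cn2)CC1` differs from compound 1 by 5-cyanopyridin-2-yl in place of 4-cyano-2-fluorophenyl on a nitrogen on an aromatic ring in a ring. For the measured compounds named here, the single measured step altered the substituent on the six-membered ring, not the ring itself, so no measured step bears directly on this change. Lacking such a guide, the step is expected to be modest and most likely not beyond the scatter, with any shift expected toward a higher number, a 1.6-fold higher number from compound 1 to compound 3 (0.20 log units; within the scatter). Compound 3 is accordingly estimated at 100 nM, within a range of 40 nM to 250 nM.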

Compound 3, half-maximal effective concentration: 794 nM
Estimate against measurement, compound 3: 7.9-fold (0.90 log units) below; measured number above the stated range.
By their numbers in this assay, from the lowest: compounds 1 and 2 (each within the scatter of the next); then compound 3.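

In this assay, exchanging 4-cyano-2-fluorophenyl for 5-cyanopyridin-2-yl on the nitrogen of the five-membered non-aromatic ring gives a 13-fold higher number from compound 1 to compound 3 (1.10 log units; beyond the scatter). Thus, this position responds strongly to a change of the aromatic ring itself, whereas the earlier step, which replaced only the cyano group, stayed within the scatter. No available evidence accounts for this large step.

The change removes fluorine and puts nitrogen into the ring at once, so the compounds shown do not separate the two. A 4-cyanophenyl group on that nitrogen would bear on this question.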